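Bromo in Place of Ethyl: A Small Change Without Precedent

This account rests on a few compounds, and the source may have more. Where it says the series, first, only, none or still open, it means among the compounds named here.

Compound 3 `CCc1ccc(C(=O)Nc2cccc(NC(=O)COc3ccc4c(=O)ccoc4c3)c2)cc1` gives 235 nM in an assay on isolated protein for inhibition of Rho-associated protein kinase 1 (Homo sapiens), read by scintillation counting, radiometric assay and 33P incorporation, with a stated time of 40 min, in the presence of a further agent that is not named here (a lower number here means a stronger inhibitor, a higher number a weaker inhibitor), the second highest of the three numbers measured. Compound 2 `CN(C)c1ccc(C(=O)Nc2cccc(NC(=O)COc3ccc4c(c3)OCCC4=O)c2)cc1` gives 144 nM, and the gap between compound 3 and compound 2 lies within the usual scatter. Compound 1 `CC(=O)c1ccc(OCC(=O)Nc2cccc(NC(=O)c3ccc(N(C)C)cc3)c2)cc1F` gives 445 nM, again within the scatter of compound 3, so none of the three can be called stronger or weaker than another with confidence. Among the measured compounds shown here, the only step that reaches beyond the scatter is a 3.1-fold lower number from compound 1 to compound 2 (0.49 log units; beyond the scatter), which swaps the group sitting on an oxygen on a saturated carbon.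

Compound 4 `O=C(COc1ccc2c(=O)ccoc2c1)Nc1cccc(NC(=O)c2ccc(Br)cc2)c1` differs from compound 3 by bromo in place of ethyl on an aromatic carbon. For the measured compounds named here, no measured pair changes anything at this part of the shared core, so the one known step gives no guide to its size or direction. With nothing to suggest a gain or a loss, the step of a 1.1-fold higher number from compound 3 to compound 4 (0.03 log units; within the scatter) is expected to stay within the scatter. Compound 4 is therefore estimated at 250 nM, with a likely range from 100 nM to 650 nM.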

Compound 4, half-maximal inhibitory concentration: 303 nM
Estimate against measurement, compound 4: 1.2-fold (0.08 log units) below, and the stated range covers the measured number.
By their numbers in this assay, from the lowest: compounds 2, 3, 4 and 1 (each within the scatter of the next, the first and the last beyond it).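

The earlier compounds shown here held no pair that changed this part of the shared core. Here, with ethyl replaced by bromo on an aromatic carbon para to a large group, this assay shows a 1.3-fold higher number from compound 3 to compound 4 (0.11 log units; within the scatter). Among the compounds shown here, for this one pair, then, a single bromine atom and an ethyl group cannot be told apart by their numbers, so the first measured change at this position leaves inhibition within normal repeat variation. Nothing measured here bears on why the two groups read alike.

On these data alone, both groups carry no hydrogen-bond donors or acceptors and no net charge, so it remains open how this position responds to a carboxylic acid or to a longer chain such as butyl. Also open, as far as these compounds go, is whether bromo reads the same when the group on the oxygen on a saturated carbon is changed.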